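Swapping a trifluoromethyl ketone for a fluorine on an oxazole

The source may hold more compounds than are shown below. What is called first, only, known or untested is meant among the compounds shown, and "the series" means these compounds.

The compounds measured so far:
compound 1, `O=C(CCCCCCc1ccccc1)c1ncc(-c2ccc([N+](=O)[O-])cc2)o1`, 50 nM
compound 2, `O=C(CCCCCCc1ccccc1)c1ncc(C(=O)C(F)(F)F)o1`, 4 nM

These values come from an assay (Rattus norvegicus) for inhibition of Fatty-acid amide hydrolase 1 (Homo sapiens); a lower number here means a stronger inhibitor, a higher number a weaker inhibitor. Compound 2 stands at the lower of the two numbers, and compound 1 sits at the higher one; the step between them, a 13-fold lower number from compound 1 to compound 2 (1.10 log units; beyond the scatter), is well beyond the scatter. Compound 3, `O=C(CCCCCCc1ccccc1)c1ncc(F)o1`, is the next compound to consider. It differs from compound 2 in one place: fluoro in place of (trifluoromethyl)carbonyl on an aromatic carbon.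

Within the data shown here, only one measured step touches this region of the shared core, namely the step from compound 1 to compound 2, in which the trifluoromethyl carbonyl entered in place of the 4-nitrophenyl group and the number fell sharply. Among the measured compounds shown here, no measured step shows what happens when the (trifluoromethyl)carbonyl is removed in favour of a single fluorine. Because the entry of this group gave a 13-fold lower number from compound 1 to compound 2 (1.10 log units; beyond the scatter), its removal is expected to move the number back upward, likely by a sizeable amount, as a step of a 50-fold higher number from compound 2 to compound 3 (1.70 log units; beyond the scatter) in this assay. Compound 3 is therefore estimated at 200 nM, with a range from 40 nM to 1000 nM.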

Compound 3, inhibition constant: 30 nM
Estimate against measurement, compound 3: 6.7-fold (0.82 log units) above; measured number below the stated range.
By their numbers in this assay, from the lowest: compound 2; then compounds 3 and 1 (each within the scatter of the next).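

In this assay, replacing the (trifluoromethyl)carbonyl with fluoro gives a 7.5-fold higher number from compound 2 to compound 3 (0.88 log units; beyond the scatter), which makes compound 2 the strongest inhibitor of the three, with its steps to both others beyond the scatter. The other comparison, a 1.7-fold lower number from compound 1 to compound 3 (0.22 log units; within the scatter), shows that fluoro and 4-nitrophenyl cannot be told apart at this position in this assay, even though one is a single atom and the other a whole ring carrying a nitro group, so among these three groups only the (trifluoromethyl)carbonyl stands apart. Nothing measured here explains why these groups rank as they do.

The three compounds leave open whether the carbonyl or the trifluoromethyl part of the group matters more, a question that a simple acetyl group or a nitrile at the same position could help to answer. They also leave open whether a plain hydrogen there would fall level with fluoro and 4-nitrophenyl, and whether the same order of groups would hold with a shorter chain on the other side of the shared core.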